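Removing a Ring Carbamate: One Change, Two Matched Pairs

The source may report more compounds than this note shows. Statements on the series, on what has been measured and on what is new or still open speak of the compounds shown alone.

Compound 1 `C=CC[C@@]12CCN[C@@H]1n1c3nc4ccc(O)cc4cc3c(=O)c3cccc2c31` carries a free amine nitrogen in a ring; in a functional assay on HeLa cells (Homo sapiens) for inhibition, read by trypan blue exclusion, with a stated time of 72 h (on this read-out higher numbers stand for weaker inhibition of growth and lower numbers for stronger inhibition of growth), compound 1 gives 19000 nM. Compound 2 `C=CC[C@@]12CCN(C(=O)OC(C)(C)C)[C@@H]1n1c3nc4ccc(O)cc4cc3c(=O)c3cccc2c31` has a tert-butoxycarbonyl on that nitrogen, and in this assay compound 2 gives 30500 nM. The change between them, (hydrogen in place of tert-butoxycarbonyl on an amine nitrogen in a ring), produced a 1.6-fold lower number from compound 2 to compound 1 (0.21 log units; within the scatter). Compound 3 `C=CC[C@@]12CCN(C(=O)OC(C)(C)C)[C@@H]1n1c3nc4ccc(O)c(CN(C)C)c4cc3c(=O)c3cccc2c31` differs from compound 2 by (dimethylamino)methyl in place of hydrogen on an aromatic carbon; in this assay compound 3 gives 35200 nM, a step of a 1.2-fold higher number from compound 2 to compound 3 (0.06 log units; within the scatter). This same (dimethylamino)methyl group also separates the core of compound 4 from the core of compound 1.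

Compound 4 `C=CC[C@@]12CCN[C@@H]1n1c3nc4ccc(O)c(CN(C)C)c4cc3c(=O)c3cccc2c31` has not yet been measured. Going by the values given here, it arises from compound 3 by hydrogen in place of tert-butoxycarbonyl on an amine nitrogen in a ring, the same change as the one that led from compound 2 to compound 1, at a place described in identical words. Because the earlier step of a 1.6-fold lower number from compound 2 to compound 1 (0.21 log units; within the scatter) stayed within the scatter, a similar step is expected for compound 4, a 1.6-fold lower number from compound 3 to compound 4 (0.20 log units; within the scatter). On that basis compound 4 is estimated at 22000 nM in this assay, with a likely range from 12000 nM to 45000 nM.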

Compound 4, concentration for 50% growth inhibition: 29300 nM
Estimate against measurement, compound 4: 1.3-fold (0.12 log units) below; measured number inside the range.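

Taking the tert-butoxycarbonyl off the amine nitrogen in a ring gave, in this assay, a 1.2-fold lower number from compound 3 to compound 4 (0.08 log units; within the scatter), and this step matches the earlier one on the other core: the same change on two cores in this assay, a 1.6-fold lower number (0.21 log units; within the scatter) from compound 2 to compound 1 and a 1.2-fold lower number (0.08 log units; within the scatter) from compound 3 to compound 4, 1.3-fold (0.13 log units) apart, within the scatter of two such steps. Adding the (dimethylamino)methyl group on the aromatic carbon of the core with the free amine gave a 1.5-fold higher number from compound 1 to compound 4 (0.19 log units; within the scatter), and this step likewise matches its earlier counterpart: the same change on two cores in this assay, a 1.2-fold higher number (0.06 log units; within the scatter) from compound 2 to compound 3 and a 1.5-fold higher number (0.19 log units; within the scatter) from compound 1 to compound 4, 1.3-fold (0.13 log units) apart, within the scatter of two such steps. Going by these compounds alone, each change therefore looks the same on both cores, but every step here lies within the scatter, so this shows only that neither change produced a readable shift on these two cores, not that either would transfer to other cores or that a larger effect would carry over.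

The compounds shown leave open whether a different group on the ring nitrogen, such as acetyl or methyl, or a cyclic amine such as morpholine in place of the dimethylamino part, would give a step beyond the scatter. From the compounds shown here alone, whether a longer chain in place of the allyl group would move the number in this assay also remains open.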